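Chloro Substitution on Two Related Thiazolidinedione Cores

A few compounds are considered here, and "the series" means these few. Any claim that something is new, unique, unknown or untested is made for them only; others in the source may bear on it.

Measured compounds:
- compound 1, `C=CCN1C(=O)S/C(=C\c2cn(-c3ccccc3)nc2-c2ccccc2)C1=O`: 50000 nM
- compound 2, `C=CCN1C(=O)S/C(=C\c2cn(-c3ccccc3)nc2-c2ccc(Cl)cc2)C1=O`: 10000 nM
- compound 3, `O=C1S/C(=C\c2cn(-c3ccccc3)nc2-c2ccccc2)C(=O)N1Cc1ccccc1`: "not evaluated" (no result reported)

In a functional assay on SH-SY5Y cells (Homo sapiens) for inhibition, with stated times of 48 h and 72 h (a lower number here means a stronger inhibitor, a higher number a weaker inhibitor), compound 1 gives 50000 nM, and compound 2 gives 10000 nM. The two differ by one change, (chloro in place of hydrogen on an aromatic carbon), and this gives a 5.0-fold lower number from compound 1 to compound 2 (0.70 log units; beyond the scatter).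

Compound 3 carries a different core; how it differs from compound 1 is phenyl in place of vinyl on a saturated chain carbon bound to an amide-type nitrogen in a ring. For compound 3 the entry in this assay reads "not evaluated" (no result reported), so no number exists for it there. Compound 4, `O=C1S/C(=C\c2cn(-c3ccccc3)nc2-c2ccccc2)C(=O)N1Cc1ccc(Cl)cc1`, is not yet measured. It stands to compound 3 as compound 2 stands to compound 1: the change is chloro in place of hydrogen on an aromatic carbon, and the place is described in the same words for both pairs, so this is the same change on a different core.

With compound 3 unmeasured, the expectation for compound 4 rests only on compound 2 and on the step of a 5.0-fold lower number from compound 1 to compound 2 (0.70 log units; beyond the scatter), assuming the change in core alters little. On that basis compound 4 is estimated at 10000 nM in this assay, with a range of 2000 nM to 50000 nM.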

Compound 4, half-maximal inhibitory concentration: 80000 nM
Compound 4: the middle estimate sits 8.0-fold (0.90 log units) below what was measured, and the stated range ends below it.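

In this assay, going by these compounds alone, compound 4 gives 80000 nM, and the one step that can be read for it is a 1.6-fold higher number from compound 1 to compound 4 (0.20 log units; within the scatter); this lies within the usual scatter, so the two compounds cannot be told apart in this assay. It does not show whether the chloro change carries over to the new core: the step of a 5.0-fold lower number from compound 1 to compound 2 (0.70 log units; beyond the scatter) belongs to the core of compound 1, and without a number for compound 3 the matching step from hydrogen to chloro on the benzyl group cannot be read. No measurement is available here that explains these results.

The compounds shown leave open how a fluoro, methoxy or carboxylic acid group would compare with chloro in this place on the aromatic ring. They also leave open what an amine or a longer chain on the amide-type nitrogen of the ring would do to inhibition in this assay.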